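A 3,5-dimethoxyphenyl swap after two limit readings

This account rests on a few compounds, and the source may have more. Where it says the series, first, only, none or still open, it means among the compounds named here.

In a functional assay on A549 cells (Homo sapiens) for antiproliferative activity, read by spectrophotometry, with a stated time of 2 days (on this read-out higher numbers stand for weaker inhibition of growth and lower numbers for stronger inhibition of growth), compound 1 `Cc1ccc(Nc2ncc(C(F)(F)F)c(N3Cc4cccc(N(C)S(C)(=O)=O)c4C3)n2)cc1C` gives > 30000 nM, which is a limit of the assay and not a number. Compound 2 `CN(c1cccc2c1CN(c1nc(Nc3ccc(C(F)(F)F)cc3)ncc1C(F)(F)F)C2)S(C)(=O)=O` gives > 30000 nM, and this too is only a limit. Going by the values given here, the only other value shown for comparison with compound 2 is therefore also a limit, so compound 2 has no exact position in this assay.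

Compound 3 `COc1cc(Nc2ncc(C(F)(F)F)c(N3Cc4cccc(N(C)S(C)(=O)=O)c4C3)n2)cc(OC)c1` carries one change from compound 2: 3,5-dimethoxyphenyl in place of 4-(trifluoromethyl)phenyl on a nitrogen on an aromatic ring. The new group therefore brings in 2 hydrogen-bond acceptors where the old one had 0, on the same nitrogen.

Among the compounds with values here, the one measured step at this place is a step that the two limits leave unreadable from compound 1 to compound 2, which exchanged 3,4-dimethylphenyl for 4-(trifluoromethyl)phenyl. That step offers no size to carry over. The evidence available is the limit of > 30000 nM in this assay, at which 2 of the 2 values shown sit, so a result close to that limit is expected, with no clear step beyond the scatter. The estimated move is an at least 1.2-fold lower number from compound 2 to compound 3 (0.07 log units; that floor lies within the scatter). Compound 3 is expected at about 25000 nM. The estimated range for compound 3 runs from 6000 nM to 60000 nM.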

Compound 3, concentration for 50% growth inhibition: 24800 nM
Compound 3: the middle estimate sits 1.0-fold (0.00 log units) above what was measured; the range from low to high includes it.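

In this assay, going by these compounds alone, compound 3 gives 24800 nM, the first exact number at this position, so the nitrogen on an aromatic ring now carries a group for which the read-out can be stated rather than only bounded. The exchange of 4-(trifluoromethyl)phenyl for 3,5-dimethoxyphenyl gives an at least 1.2-fold lower number from compound 2 to compound 3 (0.08 log units; that floor lies within the scatter), and the exchange of 3,4-dimethylphenyl for the same group gives an at least 1.2-fold lower number from compound 1 to compound 3 (0.08 log units; that floor lies within the scatter). Each step has a limit at its starting end, so only a floor can be read, and neither floor shows a change that clears the usual spread of repeated measurements: the limit of > 30000 nM in this assay, at which 2 of the 3 values shown sit.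

The compounds shown leave open how far compound 1 and compound 2 truly lie from compound 3, and whether the two methoxy groups of the 3,5-dimethoxyphenyl group both count, which a 3-methoxyphenyl group at the same nitrogen could address. They also leave open whether a phenyl ring bearing an amine or a carboxylic acid at this place would give a number clearly apart from that of compound 3 in this assay.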